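This account rests on a few compounds, and the source may have more. Where it says the series, first, only, none or still open, it means among the compounds named here.

In an assay on COS-7 cells for inhibition of patatin-like phospholipase domain-containing protein 2 (Mus musculus) (a higher number here means a weaker inhibitor, a lower number a stronger inhibitor), compound 1 `CCOC(=O)c1cccc(-c2ccc(OCC)nc2)c1` gives 130000 nM. Compound 2 `CCOc1ccc(-c2ccccc2)cc1` reaches only a limit of the assay, > 200000 nM, so no number is known for it and it stands at the limit of > 200000 nM in this assay, at which 1 of the 2 values shown sits. Compound 3 `CCOc1ccc(-c2cccc(C(=O)NC)c2)cc1` differs from compound 2 by methylcarbamoyl in place of hydrogen on an aromatic carbon. Going by the values given here, no step between two measured compounds is available to lean on, so the expected step of an at least 2.0-fold lower number from compound 2 to compound 3 (0.30 log units; that floor lies within the scatter) is a modest move toward a stronger inhibitor, with the new compound still expected to be weak. In this assay compound 3 is estimated at 100000 nM, between 30000 nM and 300000 nM.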

Compound 3, half-maximal inhibitory concentration: > 200000 nM
Compound 3 ended at the assay's limit; the forecaster's own chance of this, stated with the estimate: 35%; middle value at least 2.0-fold (0.30 log units) away from the limit.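

Compound 2 and compound 3 both give a limit of the assay rather than a number, so no step between them can be read: the limit of > 200000 nM in this assay, at which 2 of the 3 values shown sit.

As far as these compounds go, whether methylcarbamoyl in place of hydrogen on an aromatic carbon changes inhibition in this assay remains open.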